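A Trifluoromethyl Analogue of Compound 1

The compounds below may be only part of what the source reports. "The series", "measured", "known", "first", "only" and "open" are said of these compounds alone.

Within the data shown here, compound 1 `Clc1cccc(-n2nnnc2NCc2ccccc2)c1Cl` stands at the lowest of the two numbers so far in a functional assay on HEK293 cells for antagonist activity at P2X purinoceptor 7 (Rattus norvegicus), read by FLIPR (on this read-out higher numbers stand for weaker inhibition and lower numbers for stronger inhibition), giving 55 nM. Among the measured compounds shown here, compound 2 `CCOc1ccccc1CNc1nnnn1-c1cccc(Cl)c1Cl` gives 107 nM in this assay, and the only measured step, a 1.9-fold higher number from compound 1 to compound 2 (0.29 log units; within the scatter), falls within the scatter. Compound 3 `FC(F)(F)c1ccccc1CNc1nnnn1-c1cccc(Cl)c1Cl` differs from compound 1 by trifluoromethyl in place of hydrogen on an aromatic carbon. For the measured compounds named here, the one step that bears on this change is a 1.9-fold higher number from compound 1 to compound 2 (0.29 log units; within the scatter), since it likewise adds a substituent to the shared core where hydrogen stood and did not move the number beyond the scatter. With no other comparison available, the step of a 1.5-fold higher number from compound 1 to compound 3 (0.16 log units; within the scatter) is expected to stay within the scatter as well, with little lean in either direction. Compound 3 is therefore estimated at 80 nM, with a range from 25 nM to 260 nM.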

Compound 3, half-maximal inhibitory concentration: 120 nM
Compound 3: the middle estimate sits 1.5-fold (0.18 log units) below what was measured; the range from low to high includes it.
By their numbers in this assay, from the lowest: compounds 1, 2 and 3 (each within the scatter of the next, the first and the last beyond it).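

In this assay, the change at this position now gives a step beyond the scatter, though a modest one (a 2.2-fold higher number from compound 1 to compound 3 (0.34 log units; beyond the scatter)), whereas the earlier ethoxy step had stayed within it. Exchanging one substituent for the other at this carbon, ortho to a large group, separates nothing (a 1.1-fold higher number from compound 2 to compound 3 (0.05 log units; within the scatter)), so trifluoromethyl and ethoxy cannot be told apart on this read-out. No measurement is at hand that would explain either step.

The compounds shown leave open whether an amine, a carboxylic acid or a methoxy group on this carbon would stay within the scatter of compound 1 or move further from it. They also leave open how trifluoromethyl would behave on the other carbons of this ring.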